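Dichlorophenyl in place of phenyl: expected hepatocyte clearance

The compounds below may be only part of what the source reports. "The series", "measured", "known", "first", "only" and "open" are said of these compounds alone.

Compound 1 `O=C(N[C@H]1CN(S(=O)(=O)c2ccccc2)C[C@@H]1C(=O)N[C@H]1CCCNC1)c1cc(-c2ccccc2)on1`: 6.8 uL/min
Compound 2 `O=C(N[C@H]1CN(S(=O)(=O)c2ccccc2)C[C@@H]1C(=O)N[C@H]1CCCNC1)c1nnc(-c2ccc(F)cc2)s1`: 1.2 uL/min

In an ADME assay on cells (Hepatocyte, Rattus norvegicus) for metabolic stability (on this read-out higher numbers stand for fast clearance and lower numbers for slow clearance), compound 1 gives the higher of the two numbers; its nearest neighbour is compound 2, reached by a 5.7-fold lower number from compound 1 to compound 2 (0.75 log units; beyond the scatter). Compound 3 `O=C(N[C@H]1CN(S(=O)(=O)c2ccccc2)C[C@@H]1C(=O)N[C@H]1CCCNC1)c1cc(-c2ccc(Cl)cc2Cl)on1` differs from compound 1 by 2,4-dichlorophenyl in place of phenyl on an aromatic carbon. Among the compounds with values here, no measured step touches this phenyl; the one known step alters a different ring, so it gives no guidance on the change. Compound 3 is therefore expected to sit close to compound 1, with a 1.0-fold higher number from compound 1 to compound 3 (0.01 log units; within the scatter) expected to stay within the scatter. The estimate for compound 3 is 7 uL/min, between 2.5 uL/min and 20 uL/min.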

Compound 3, intrinsic clearance in a liver preparation (reported as CLH), per the amount of preparation that the assay uses: < 1 uL/min
Compound 3: a limit, no number; the forecaster's own chance of this, stated with the estimate: 5%; middle value at least 7.0-fold (0.84 log units) from the limit.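

The phenyl next to the ring oxygen turns out to be a sensitive place in the core of compound 1: 2,4-dichlorophenyl in place of phenyl gives an at least 6.8-fold lower number from compound 1 to compound 3 (0.83 log units; beyond the scatter) in this assay. The earlier step changed the five-membered aromatic ring and its aryl group together, whereas this one changes only the aryl group. Compound 3 stands at a limit of the assay, not at a number: the limit of < 1 uL/min in this assay, at which 1 of the 3 values shown sits.

Both chlorines enter together, so the compounds shown do not tell how much of the step belongs to either one. Going by these compounds, whether a single chlorine, a fluorine or a methoxy group on this phenyl would give a similar step remains open.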